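The compounds below may be only part of what the source reports. "The series", "measured", "known", "first", "only" and "open" are said of these compounds alone.

Three compounds have been measured so far in a toxicity assay on HEK-293T cells (Homo sapiens) for cytotoxicity, read by MTT assay, with a stated time of 72 h (a higher number here means a weaker inhibitor, a lower number a stronger inhibitor), as follows:

- compound 1 `O=C1c2c[n+]([O-])c3ccccc3c2C(=O)c2c1c1ccccc1n2CCCCN1CCNCC1` gives 760 nM
- compound 2 `O=C1c2c[n+]([O-])c3ccccc3c2C(=O)c2c1c1ccccc1n2Cc1cn([C@H]2C[C@H](O)[C@@H](CO)O2)nn1` gives 3600 nM
- compound 3 `O=C1c2c[n+]([O-])c3ccccc3c2C(=O)c2c1c1ccccc1n2Cc1cn([C@@H]2O[C@H](CO)[C@@H](O)[C@H](O)[C@H]2O)nn1` gives 940 nM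

Compound 1 and compound 3 lie within the scatter of each other, and compound 2 stands apart from both with the highest number.

The compound still to be measured is compound 4 `O=C1c2c[n+]([O-])c3ccccc3c2C(=O)c2c1c1ccccc1n2CCCN1CCC(O)CC1` and its change from compound 1 is this: 4-hydroxypiperidin-1-yl in place of (piperazin-1-yl)methyl on a saturated chain carbon, three bonds along the chain from an aromatic nitrogen and, cut one bond further out, it reads 4-(piperazin-1-yl)butyl to 3-(4-hydroxypiperidin-1-yl)propyl.

Within the data shown here, only one measured step is available, a 3.8-fold lower number from compound 2 to compound 3 (0.58 log units; beyond the scatter) on exchanging 4-hydroxy-5-(hydroxymethyl)oxolan-2-yl for 3,4,5-trihydroxy-6-(hydroxymethyl)oxan-2-yl on an aromatic nitrogen. That exchange involves neither group at issue here, so it offers a rough sense of size and no direction. A small step in this assay is therefore expected, probably no larger than that one. Among the measured compounds shown here, the data fix no direction, and the estimate leans only slightly toward a higher number, as compound 2 at 3600 nM is the one value well clear of compound 1.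

The expected step is a 1.4-fold higher number from compound 1 to compound 4 (0.16 log units; within the scatter) in this estimate. For compound 4 the estimated value is 1100 nM with 380 nM to 3200 nM as the expected range.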

Compound 4, half-maximal inhibitory concentration: 170 nM
Compound 4: middle estimate off by 6.5-fold (0.81 log units), on the high side; the measured number lies below the stated range.
By their numbers in this assay, from the lowest: compound 4; then compounds 1 and 3 (each within the scatter of the next); then compound 2.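

In this assay, among these compounds, the side chain proves sensitive to change at this place, a saturated chain carbon three bonds along the chain from an aromatic nitrogen: 4-hydroxypiperidin-1-yl in place of (piperazin-1-yl)methyl gives a 4.5-fold lower number from compound 1 to compound 4 (0.65 log units; beyond the scatter), whereas the only earlier step concerned a group on an aromatic nitrogen. The leaving and entering groups have equal counts of heavy atoms, hydrogen-bond donors and hydrogen-bond acceptors and differ in atom makeup by one nitrogen against one oxygen, so a step beyond the scatter can arise here without any change in those counts. No measurement shown offers an explanation for this step.

Read one bond further out, the change is 4-(piperazin-1-yl)butyl to 3-(4-hydroxypiperidin-1-yl)propyl, so the compounds shown leave open how much of the step goes with the shorter chain and how much with the ring and its hydroxyl. A 3-(piperazin-1-yl)propyl chain would address the first part, while a plain piperidine or a morpholine on the same propyl chain would address the second.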